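Testing a Naphthyl Replacement Against Two Close Analogues

This account rests on a few compounds, and the source may have more. Where it says the series, first, only, none or still open, it means among the compounds named here.

Compound 1, `O=S(=O)(NCCCNCc1ccc(Cl)c(Cl)c1)c1cc(C(F)(F)F)cc(C(F)(F)F)c1`: 1800 nM in a functional assay on Capan-2 cells (Homo sapiens) for inhibition, read by MTT assay, with a stated time of 72 h; a higher number here means a weaker inhibitor of growth, a lower number a stronger inhibitor of growth
Compound 2, `O=S(=O)(NCCCNCc1ccc(C(F)(F)F)cc1)c1cc(C(F)(F)F)cc(C(F)(F)F)c1`: 2000 nM in this assay

On the numbers shown, compound 2 and compound 1 lie within the scatter of each other, so neither can be placed above the other in this assay. Compound 3, `O=S(=O)(NCCCNCc1cccc2ccccc12)c1cc(C(F)(F)F)cc(C(F)(F)F)c1`, differs from compound 2 by naphthalen-1-yl in place of 4-(trifluoromethyl)phenyl on a saturated chain carbon bound to an amine nitrogen. Going by the values given here, only one measured step touches this same place on the shared core, a 1.1-fold higher number from compound 1 to compound 2 (0.05 log units; within the scatter), and it moved the number by less than the scatter. That single step is the whole basis for any expectation, and it points to no change beyond the scatter in this assay. Compound 3 is therefore expected to sit close to compound 2, with an expected step of no change at the digits printed from compound 2 to compound 3 (within the scatter). The estimate for compound 3 is 2000 nM, with a range from 800 nM to 5000 nM.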

Compound 3, concentration for 50% growth inhibition: 2700 nM
For compound 3 the middle estimate is 1.4-fold (0.13 log units) below the measured one; low and high end bracket the measured number.
By their numbers in this assay, from the lowest: compounds 1, 2 and 3 (each within the scatter of the next).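

In this assay, naphthalen-1-yl in place of 4-(trifluoromethyl)phenyl gives a 1.4-fold higher number from compound 2 to compound 3 (0.13 log units; within the scatter) and, in place of 3,4-dichlorophenyl, gives a 1.5-fold higher number from compound 1 to compound 3 (0.18 log units; within the scatter) in the same assay. The earlier pair compared only groups with a single aromatic ring, whereas this group has 2 six-membered aromatic rings of carbon only and no halogen, and still the three compounds cannot be told apart at this place on a saturated chain carbon bound to an amine nitrogen. No measurement available here accounts for this result.

Still open, going by these compounds, is whether a carboxylic acid or an amine on the aromatic ring would move the number beyond the scatter. On these data alone, it is also open whether a longer chain in the shared core would do so.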